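Replacing the 4-methoxyphenyl Chain End with Cyclohexyl

The compounds below may be only part of what the source reports. "The series", "measured", "known", "first", "only" and "open" are said of these compounds alone.

In a functional assay on PANC-1 cells (Homo sapiens) for cytotoxicity, read by WST assay, with a stated time of 24 h (on this read-out lower numbers stand for stronger inhibition and higher numbers for weaker inhibition), compound 1 `O=C(CCCCCCCCc1ccc(C(F)(F)F)cc1)N1CCCCC1` gives 54000 nM and compound 2 `COc1ccc(CCCCCCCCC(=O)N2CCCCC2)cc1` gives 89300 nM. Going by the values given here, these are the only two numbers so far, and they lie within the scatter of each other. Compound 3 `O=C(CCCCCCCCC1CCCCC1)N1CCCCC1` has not yet been measured. Its difference from compound 2 is cyclohexyl in place of 4-methoxyphenyl on a saturated chain carbon, eight bonds along the chain from a carbonyl carbon. Among the compounds with values here, only one measured step bears on this, a 1.7-fold higher number from compound 1 to compound 2 (0.22 log units; within the scatter), with methoxy in place of trifluoromethyl on an aromatic carbon. Within the data shown here, that step leaves the aromatic ring in place, so it is an indirect guide, and no measured compound carries a non-aromatic ring here. On this evidence, no change beyond the scatter is expected in this assay, and no direction is favoured. The expected step is a 1.3-fold lower number from compound 2 to compound 3 (0.11 log units; within the scatter). Compound 3 is estimated at 70000 nM, with an expected range of 28000 nM to 170000 nM.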

Compound 3, half-maximal inhibitory concentration: > 100000 nM
Compound 3: a limit, no number; the forecaster's own chance of this, stated with the estimate: 10%; middle value at least 1.4-fold (0.15 log units) away from the limit.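

In this assay, compound 3 gives only a limit of the assay, not a number: the limit of > 100000 nM in this assay, at which 1 of the 3 values shown sits.

Cyclohexyl in place of 4-methoxyphenyl on a saturated chain carbon, eight bonds along the chain from a carbonyl carbon, gives an at least 1.1-fold higher number from compound 2 to compound 3 (0.04 log units; that floor lies within the scatter). The earlier compounds shown here changed only a group on the aromatic ring, whereas this result tests the ring itself and shows no lower number with the non-aromatic ring, though the floor of the step does not separate compound 2 and compound 3 beyond the scatter.

Going by these compounds alone, how far the number rises with cyclohexyl stays open, as the limit gives no size for the step. Also open, from the compounds shown here alone, is how a pyridine ring in this place, or an amine or a carboxylic acid on the cyclohexyl ring, would read.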